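This account rests on a few compounds, and the source may have more. Where it says the series, first, only, none or still open, it means among the compounds named here.

Compound 1 `CNCCCNc1c(F)cc2c(=O)c(C(=O)O)cn(Cc3ccc(-c4ccccc4)cc3)c2c1OC`, compound 2 `NC[C@@H]1CCN(c2cc3c(cc2F)c(=O)c(C(=O)O)cn3Cc2ccc(-c3ccc(F)cc3)cc2)C1` and compound 3 `CNCCCNc1cc2c(cc1F)c(=O)c(C(=O)O)cn2Cc1ccc(-c2ccccc2)cc1` were tested in an assay on isolated protein for inhibition of DNA topoisomerase 1 (Homo sapiens), with a stated time of 15 min; a lower number here means a stronger inhibitor, a higher number a weaker inhibitor. Compound 1 gives 101000 nM, compound 2 gives 69600 nM, and compound 3 gives 63600 nM. Compounds 3 and 1 differ in one place: methoxy in place of hydrogen on an aromatic carbon. That change gave a 1.6-fold higher number from compound 3 to compound 1 (0.20 log units; within the scatter). Compound 4 `COc1c(N2CC[C@@H](CN)C2)c(F)cc2c(=O)c(C(=O)O)cn(Cc3ccc(-c4ccc(F)cc4)cc3)c12` has not yet been measured in this assay; it arises from compound 2 by the same kind of change: methoxy in place of hydrogen on an aromatic carbon. The surroundings are not identical, since in compound 1 the entering group sits ortho to a (3-(methylamino)propyl)amino group, while in compound 4 it sits ortho to a 3-(aminomethyl)pyrrolidin-1-yl group. How the cores of compound 2 and compound 3 differ is not broken down here. The step expected here is a 1.5-fold higher number from compound 2 to compound 4 (0.18 log units; within the scatter), because the earlier step of a 1.6-fold higher number from compound 3 to compound 1 (0.20 log units; within the scatter) stayed within the scatter. Compound 4 is therefore estimated at 105000 nM, with a likely range from 50000 nM to 220000 nM.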

Compound 4, half-maximal inhibitory concentration: 60900 nM
The estimate for compound 4 lay 1.7-fold (0.24 log units) above the measured number; measured number inside the range.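

In this assay, methoxy in place of hydrogen on the aromatic carbon gave a 1.1-fold lower number from compound 2 to compound 4 (0.06 log units; within the scatter), so neither this step nor the earlier one on the other core goes beyond the usual scatter. The two steps also agree with each other as far as these measurements can tell: the same change on two cores in this assay, a 1.6-fold higher number (0.20 log units; within the scatter) from compound 3 to compound 1 and a 1.1-fold lower number (0.06 log units; within the scatter) from compound 2 to compound 4, 1.8-fold (0.26 log units) apart, within the scatter of two such steps. On these two cores the change carried over without a clear effect, but two pairs cannot show that it would be equally silent on other cores, nor can they rule out a small real effect hidden in the scatter.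

The compounds shown leave open what an ethoxy group or a chloro group on the same aromatic carbon would do. They also leave open what an amide in place of the carboxylic acid would do.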